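A few compounds are considered here, and "the series" means these few. Any claim that something is new, unique, unknown or untested is made for them only; others in the source may bear on it.

Compound 1 `COc1ccc(N(C)c2ccnc(Cl)n2)cc1`: 611 nM
Compound 2 `COc1ccc(N(C)c2ccnc(Cl)n2)cc1OCCCCBr`: 591 nM
Compound 3 `COc1ccc(N(C)c2cc(C)nc(C)n2)cc1`: 277 nM

These values come from a functional assay on A549 cells (Homo sapiens) for antiproliferative activity, read by MTT assay, with a stated time of 48 h; on this read-out higher numbers stand for weaker inhibition and lower numbers for stronger inhibition. Among the three, compound 3 has the lowest number, 277 nM, and so the strongest inhibition. The next compound, compound 4 `COc1ccc(N(C)c2cc(C)nc(C)n2)cc1F`, carries fluoro in place of hydrogen on an aromatic carbon of compound 3: fluoro in place of hydrogen on an aromatic carbon. Going by the values given here, only one measured step offers a comparison, since it also replaces hydrogen on an aromatic carbon, there with 4-bromobutoxy: a 1.0-fold lower number from compound 1 to compound 2 (0.01 log units; within the scatter). That is a much larger group on a different core, so it is only a loose guide, but it suggests no change beyond the scatter in this assay. The expected step is a 1.1-fold lower number from compound 3 to compound 4 (0.03 log units; within the scatter). The estimated value for compound 4 is 260 nM, with a range from 120 nM to 560 nM.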

Compound 4, half-maximal inhibitory concentration: 632 nM
Compound 4: middle estimate off by 2.4-fold (0.39 log units), on the low side; measured number outside the range, above it.
By their numbers in this assay, from the lowest: compound 3; then compounds 2, 1 and 4 (each within the scatter of the next).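

Even a single fluorine, ortho to a methoxy group, matters in this assay: the change gives a 2.3-fold higher number from compound 3 to compound 4 (0.36 log units; beyond the scatter), so inhibition weakens. The earlier replacement of hydrogen, with 4-bromobutoxy on the core of compound 1, gave only a 1.0-fold lower number from compound 1 to compound 2 (0.01 log units; within the scatter), so that step gave no sign that a small group here could shift the result. Nothing measured here explains the loss. On these data alone, whether it is particular to fluoro stays open, as chloro, hydroxy or an amine in the same place on compound 3 could show. Also open, as far as these compounds go, is whether fluoro acts alike on the core of compound 1.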